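From compound 2 to compound 3: a tert-butyl step

The source may hold more compounds than are shown below. What is called first, only, known or untested is meant among the compounds shown, and "the series" means these compounds.

Of the compounds shown here, two have been read so far, compound 1 (`Cc1ccc(CC(Oc2ccc(C(C)C)cc2)C(=O)O)cc1`) and compound 2 (`O=C(O)C(Cc1ccc(Cl)cc1)Oc1ccccc1`), both in a functional assay on the whole organism for inhibition, with Rattus norvegicus as the target; a higher number here means that more compound is needed for the effect, a lower number that less compound is needed. Compound 2 stands at > 25 mg/kg, which is a limit and not a number. Compound 1 stands at < 50 mg/kg, which is also a limit. Within the data shown here, these two limits leave the order of the pair open, and no measured step exists to calibrate the next change.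

Compound 3 (`CC(C)(C)c1ccc(OC(Cc2ccc(Cl)cc2)C(=O)O)cc1`) takes compound 2 and puts tert-butyl in place of hydrogen on an aromatic carbon, para to a large group: tert-butyl in place of hydrogen on an aromatic carbon. A modest step towards a lower dose in this assay is expected, possibly not beyond the scatter, and the estimated change is an at least 1.2-fold lower number from compound 2 to compound 3 (0.09 log units; that floor lies within the scatter). For compound 3 the expected dose is 20 mg/kg, with an estimated range of 8 mg/kg to 50 mg/kg.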

Compound 3, dose for half-maximal effect: 25 mg/kg
Estimate against measurement, compound 3: 1.3-fold (0.10 log units) below; low and high end bracket the measured number.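

Among these compounds, compound 3 gives 25 mg/kg in this assay, the first plain number rather than a limit. Tert-butyl in place of hydrogen on this aromatic carbon, para to a large group, gives a number no higher from compound 2 to compound 3 (the limit leaves the size open), so this position takes the added 4 heavy atoms with no rise in the number. The size of that step cannot be read because compound 2 carries only a limit: the limit of > 25 mg/kg in this assay, at which 1 of the 3 values shown sits.

On these data alone, whether tert-butyl lowers the dose at all, or by how much, remains open. Also open, as far as these compounds go, is how an amine or a methoxy group on the same aromatic carbon would read in this assay against the value of compound 3.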